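Removing the methoxy group of compound 2

A few compounds are considered here, and "the series" means these few. Any claim that something is new, unique, unknown or untested is made for them only; others in the source may bear on it.

Compound 1 `COc1ccccc1C(=O)CSc1nc2ccccc2[nH]1` and compound 2 `COc1ccc(C(=O)CSc2nc3ccccc3[nH]2)cc1` share one core and differ only in where the methoxy sits. In a functional assay on HT-29 cells (Homo sapiens) for inhibition, read by flow cytometry, tested at 10 uM (on this read-out higher numbers stand for more inhibition at the one concentration tested (going by the name of the read-out) and lower numbers for less inhibition), compound 1 gives 34.9% and compound 2 gives 52.6%, the higher of the two numbers measured, compound 1 lying below it by more than the usual scatter. Compound 3 `O=C(CSc1nc2ccccc2[nH]1)c1ccccc1` carries the change (hydrogen in place of methoxy on an aromatic carbon). Among the measured compounds shown here, no measured step of this kind is at hand, so its direction is uncertain. A modest loss is expected, a number 10.6 percentage points lower from compound 2 to compound 3 (beyond the scatter), near the edge of the scatter. Compound 3 is estimated in this assay at 42%, between 25% and 60%.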

Compound 3, a percentage reported as inhibition, at one concentration (the size of the read-out at that concentration, not a potency): "not active" (no number reported)
Nothing numeric was reported for compound 3, and the estimate cannot be compared.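

Among the compounds shown here, compound 3 is reported as not active, without a number, and no step from compound 2 to it can be read in this assay. From the compounds shown here alone, how large the effect of removing the methoxy group is stays open. No evidence bears on this result.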